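Pyridin-2-yl for phenyl on the carbonyl carbon of compound 2

The source may hold more compounds than are shown below. What is called first, only, known or untested is meant among the compounds shown, and "the series" means these compounds.

Three compounds carry numbers in a functional assay on MCF7 cells (Homo sapiens) for antiproliferative activity, with a stated time of 5 days; on this read-out lower numbers stand for stronger inhibition and higher numbers for weaker inhibition. Compound 1 `CCCCc1ccc2[nH]c(-c3ccc(CC)cc3)c(C=O)c2c1` gives 58 nM; compound 2 `CCCCc1ccc2[nH]c(-c3ccc(OC)cc3)c(/C=N/NC(=O)c3ccccc3)c2c1` gives 130 nM; compound 3 `CCCCc1ccc2[nH]c(-c3ccc(CC)cc3)c(/C=N/NC(=O)c3ccncc3)c2c1` gives 150 nM. Compound 2 stands second highest of the three: the number of compound 3 lies within the scatter of it, while the number of compound 1 is lower by a gap beyond the scatter.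

Compound 4 `CCCCc1ccc2[nH]c(-c3ccc(OC)cc3)c(/C=N/NC(=O)c3ccccn3)c2c1` differs from compound 2 in one place, (pyridin-2-yl in place of phenyl on a carbonyl carbon), on a carbonyl carbon whose other neighbour is an amide-type nitrogen. Among the compounds with values here, no step between measured compounds isolates this change, so nothing measured speaks for or against it. In this assay no step beyond the scatter is expected in either direction. Compound 4 is estimated at 130 nM, with a range from 55 nM to 320 nM. The step of no change at the digits printed from compound 2 to compound 4 (within the scatter) is expected to stay within the scatter.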

Compound 4, half-maximal inhibitory concentration: 160 nM
For compound 4 the middle estimate is 1.2-fold (0.09 log units) below the measured one; the range from low to high includes it.
By their numbers in this assay, from the lowest: compound 1; then compounds 2, 3 and 4 (each within the scatter of the next).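

In this assay, the step at this position reads a 1.2-fold higher number from compound 2 to compound 4 (0.09 log units; within the scatter), so this carbonyl carbon accepts pyridin-2-yl in place of phenyl, with its one hydrogen-bond acceptor, without a step beyond the scatter. The earlier compounds shown here held no pair isolating this position. Nothing measured on the compounds accounts for this outcome or bears on it. Open, on these data alone, is whether a non-aromatic group on this carbonyl carbon, such as piperidin-4-yl or a short chain carrying an amine, would give a step beyond the scatter.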